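The source may report more compounds than this note shows. Statements on the series, on what has been measured and on what is new or still open speak of the compounds shown alone.

Series notes. Two chalcone-type compounds have been run so far. Compound 1 `COc1cccc(C(=O)/C=C/c2cc(Br)ccc2O)c1` carries a bromo group on its phenol ring; in a functional assay on MCF7 cells (Homo sapiens) for antiproliferative activity, read by sulforhodamine B assay, with a stated time of 72 h, tested at 30 uM (a lower number here means a stronger effect, a higher number a weaker effect of the compound at the concentration tested), compound 1 gives 28.3%. Compound 2 `Cc1ccc(C(=O)/C=C/c2cc(Cl)ccc2O)cc1` carries a chloro group at the same place; in this assay compound 2 gives 27.7%. The two numbers lie within the usual scatter of each other, so nothing separates compound 1 from compound 2 in this assay.

Compound 3 `Cc1ccc(C(=O)/C=C/c2cc(Br)ccc2O)cc1` is not yet measured. It differs from compound 2 by bromo in place of chloro on an aromatic carbon. Going by the values given here, no step between measured compounds is available for this change, and the pair of measured compounds does not show the two halogens apart. The step expected a number 0.3 percentage points higher from compound 2 to compound 3 (within the scatter) is none beyond the scatter, in either direction. Compound 3 is therefore estimated at 28% in this assay, with a range of 15% to 42%.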

Compound 3, a percentage reported as activity, at one concentration (the size of the read-out at that concentration, not a potency): 31.8%
Compound 3: the middle estimate sits 3.8 percentage points below what was measured; the measured number falls inside the stated range.
By their numbers in this assay, from the lowest: compounds 2, 1 and 3 (each within the scatter of the next).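

Bromo in place of chloro on this aromatic carbon, para to a hydroxy group, can now be read as a single change in this assay, giving a number 4.1 percentage points higher from compound 2 to compound 3 (within the scatter). Going by these compounds alone, this is the first direct comparison of the two halogens at this place with the rest of the structure held constant, and the step does not separate them. Within this pair, the place tolerates either halogen without a difference beyond the scatter; no measurement at hand bears on what lies behind this result.

The compounds shown leave open whether a group of another kind at this place, such as an amine or a carboxylic acid, would move the number beyond the scatter. They also leave open whether the same halogen exchange would read alike with a methoxy group in place of the methyl group.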